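Adding one methoxy to the terminal phenyl of compound 2

This account rests on a few compounds, and the source may have more. Where it says the series, first, only, none or still open, it means among the compounds named here.

Values in a functional assay on THP-1 cells (Homo sapiens) for inhibition, read by sulforhodamine B assay, with a stated time of 48 h, tested at 50 uM; a higher number here means more inhibition of growth at the concentration tested, a lower number less inhibition of growth:
Compound 1 `COc1ccc(/C=C/C(=O)/C=C/c2ccc(OCc3cn(CCOc4cc(=O)oc5ccccc45)nn3)c(OC)c2)cc1OC`: 90%
Compound 2 `COc1cc(/C=C/C(=O)/C=C/c2ccccc2)ccc1OCc1cn(CCOc2cc(=O)oc3ccccc23)nn1`: 61%

Compound 2, at 61%, holds the lower of the two values. Compound 3 `COc1ccccc1/C=C/C(=O)/C=C/c1ccc(OCc2cn(CCOc3cc(=O)oc4ccccc34)nn2)c(OC)c1` has methoxy in place of hydrogen on an aromatic carbon, ortho to a large group, turning phenyl into 2-methoxyphenyl: methoxy in place of hydrogen on an aromatic carbon. Going by the values given here, only one measured step bears on this change, a number 29 percentage points lower from compound 1 to compound 2 (beyond the scatter), which swaps 3,4-dimethoxyphenyl for phenyl. With one methoxy entering, at a different place, a rise smaller than that step is expected in this assay, though this rests on a single pair. The estimated step is a number 13 percentage points higher from compound 2 to compound 3 (beyond the scatter). The expected value for compound 3 is 74%, with an estimated range of 58% to 91%.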

Compound 3, percent growth inhibition at one concentration: 75%
Beside the measured number, compound 3's estimate is 1 percentage points below it; measured number inside the range.
By their numbers in this assay, from the lowest: compound 2; then compound 3; then compound 1.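

In this assay, one methoxy on the phenyl, giving 2-methoxyphenyl, is enough for a clear rise (a number 14 percentage points higher from compound 2 to compound 3 (beyond the scatter)). That single group does not match the 3,4-dimethoxyphenyl of compound 1 (a number 15 percentage points lower from compound 1 to compound 3 (beyond the scatter)), so the terminal ring's substitution still matters beyond this one methoxy. (No measurement at hand gives a reason for either step).

As far as these compounds go, whether the rise belongs to methoxy specifically remains open, since a hydroxy group or an amine at this place could do the same. Also open, from the compounds shown here alone, is how much depends on where on the phenyl the methoxy sits.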